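A few compounds are considered here, and "the series" means these few. Any claim that something is new, unique, unknown or untested is made for them only; others in the source may bear on it.

Measured so far in a functional assay on HCT-116 cells (Homo sapiens) for antiproliferative activity; a lower number here means a stronger inhibitor, a higher number a weaker inhibitor:
- Compound 1 `Cc1c2c(n3c1CCN(C(=O)[C@H](C)N)CC[C@H](C)Nc1cc-3ccc1C(N)=O)CC(C)(C)CC2=O`: 314 nM
- Compound 2 `Cc1c2c(n3c1CCCN(C)[C@@H](C)[C@H](C)Nc1cc-3ccc1C(N)=O)CC(C)(C)CC2=O`: 51 nM

Compound 2 has the lower number of the two, which makes it the stronger inhibitor, and its gap to compound 1 lies beyond the usual scatter of repeated measurements. Compound 3 `COCCC(=O)N1CCCc2c(C)c3c(n2-c2ccc(C(N)=O)c(c2)N[C@@H](C)[C@@H]1C)CC(C)(C)CC3=O` has not been measured yet. Set against compound 2, its change is (2-methoxyethyl)carbonyl in place of methyl on an amine nitrogen in a ring. In words, (2-methoxyethyl)carbonyl stands in place of methyl on an amine nitrogen in a ring. For the measured compounds named here, no measured pair isolates this change, so any forecast is loose. The nearest hint is compound 1, which also carries a carbonyl on a ring nitrogen and gives 314 nM, although its structure differs from compound 2 elsewhere too. On that single hint, a weaker result than compound 2 is expected, probably by a step beyond the scatter. The estimated step is a 3.1-fold higher number from compound 2 to compound 3 (0.50 log units; beyond the scatter). In this assay, the expected value for compound 3 is 160 nM, with an estimated range of 45 nM to 600 nM.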

Compound 3, half-maximal inhibitory concentration: 55 nM
Beside the measured number, compound 3's estimate is 2.9-fold (0.46 log units) above it; measured number inside the range.
By their numbers in this assay, from the lowest: compounds 2 and 3 (each within the scatter of the next); then compound 1.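

In this assay, for the compounds shown here, putting (2-methoxyethyl)carbonyl in place of methyl on this amine nitrogen in a ring gives a 1.1-fold higher number from compound 2 to compound 3 (0.03 log units; within the scatter), the first direct reading of a change at this position. The entering group has 6 heavy atoms against 1 and 2 hydrogen-bond acceptors against 0, so in this pair, a much larger group with a carbonyl on the ring nitrogen carries no measurable cost in antiproliferative activity on these cells. No other measurement here bears on the reason for this result.

This is one pair with one entering group, so it cannot show how far the tolerance extends, or whether it is the carbonyl, the chain or the methoxy end that matters. A simple acetyl group, a longer chain, or a chain ending in an amine or a carboxylic acid on the same nitrogen would help to separate these parts, and the same change on a different version of the shared core would test whether the result holds beyond this pair.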